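The compounds below may be only part of what the source reports. "The series", "measured", "known", "first", "only" and "open" are said of these compounds alone.

Measured so far in a functional assay, with a stated time of 20 min, tested at 2 mg/mL; on this read-out lower numbers stand for a weaker effect and higher numbers for a stronger effect at the one concentration tested:
compound 1 `COc1ccc(N2C(=O)[C@H]3[C@H](ON4[C@@H]3C(=O)N(C)[C@@]43C[C@H](C)CC[C@H]3C(C)C)C2=O)cc1`: 61.7%
compound 2 `Cc1ccc(N2C(=O)[C@H]3[C@H](ON4[C@@H]3C(=O)N(C)[C@@]43C[C@H](C)CC[C@H]3C(C)C)C2=O)c(C)c1`: 72%

Compound 2 stands highest of the two numbers in this assay, its nearest neighbour being compound 1. Compound 3 `CC(C)[C@@H]1CC[C@@H](C)C[C@@]12N(C)C(=O)[C@@H]1[C@H]3C(=O)N(c4ccc5ccccc5c4)C(=O)[C@H]3ON12` differs from compound 2 by naphthalen-2-yl in place of 2,4-dimethylphenyl on an amide-type nitrogen in a ring. Going by the values given here, the one measured step that bears on this also exchanged the aryl group on that nitrogen and was modest, a number 10.3 percentage points higher from compound 1 to compound 2 (beyond the scatter). A comparable or smaller step, in either direction, and possibly none beyond the scatter, is expected here. Compound 3 is therefore estimated at 74%, within 56% to 90%, which means an expected step of a number 2 percentage points higher from compound 2 to compound 3 (within the scatter).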

Compound 3, a percentage reported as activity, at one concentration (the size of the read-out at that concentration, not a potency): 35%
Compound 3: middle estimate off by 39 percentage points, on the high side; the whole stated range lies above it.
By their numbers in this assay, from the lowest: compound 3; then compound 1; then compound 2.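

In this assay, the aryl group on the amide-type nitrogen proved able to move the read-out much further than the earlier pair showed: naphthalen-2-yl gives a number 37 percentage points lower from compound 2 to compound 3 (beyond the scatter) and a number 26.7 percentage points lower from compound 1 to compound 3 (beyond the scatter). Among these compounds, the group with two aromatic rings therefore stands below both groups with one. Nothing available explains this fall. The compounds shown leave open whether a single-ring group such as pyridin-3-yl or cyclohexyl would keep the higher numbers. They also leave open whether naphthalen-1-yl would fall as far.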